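The source may hold more compounds than are shown below. What is called first, only, known or untested is meant among the compounds shown, and "the series" means these compounds.

Measured so far in an ADME assay on MT4 cells (Homo sapiens) for cytotoxicity, read by MTT assay; on this read-out lower numbers stand for higher toxicity in this test and higher numbers for lower toxicity in this test:
- compound 1 `Cc1nc(NC(=O)NC2CCCCC2)c(C)c(C(OC(C)(C)C)C(=O)O)c1-c1ccc2c(c1)NCCO2`: 30000 nM
- compound 2 `Cc1nc(NC(=O)NC2CCCCC2)c(C)c(C(OC(C)(C)C)C(=O)O)c1-c1ccc(C(F)(F)F)cc1`: 9800 nM
- compound 3 `COc1ccc(Nc2nc(C)c(-c3ccc(C)c(C)c3)c(C(OC(C)(C)C)C(=O)O)c2C)cc1`: 28000 nM

Compound 3 stands second highest of the three numbers in this assay. Its nearest neighbour is compound 1, whose number lies within the scatter of that of compound 3; compound 2 sits furthest away, with a lower number beyond the scatter.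

Compound 4 `Cc1ccc(-c2c(C)nc(NC(=O)NCc3ccccc3)c(C)c2C(OC(C)(C)C)C(=O)O)cc1C` is not yet measured. Relative to compound 3 the change is benzylcarbamoyl in place of 4-methoxyphenyl on a nitrogen on an aromatic ring; the rest of the shared core and the dimethylphenyl group are kept.

Within the data shown here, the only measured step, a 3.1-fold lower number from compound 1 to compound 2 (0.49 log units; beyond the scatter), concerns the aryl group on an aromatic carbon and not the nitrogen substituent, so it does not bear directly on the change at hand. What the numbers of compound 1 and compound 3 show is that two quite different groups on that nitrogen give values within the scatter of each other. On this basis a step of no size beyond the scatter is expected for compound 4, a 1.1-fold lower number from compound 3 to compound 4 (0.05 log units; within the scatter) being the expected outcome. Compound 4 is estimated at 25000 nM in this assay, with a range from 10000 nM to 60000 nM.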

Compound 4, half-maximal cytotoxic concentration: 17000 nM
The estimate for compound 4 lay 1.5-fold (0.17 log units) above the measured number, within the range that was stated.
By their numbers in this assay, from the lowest: compounds 2, 4, 3 and 1 (each within the scatter of the next, the first and the last beyond it).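

In this assay, among these compounds, a 1.6-fold lower number from compound 3 to compound 4 (0.22 log units; within the scatter) is the first step read at the nitrogen on an aromatic ring, as the earlier step concerned only the aryl group on an aromatic carbon. At this position, benzylcarbamoyl can therefore take the place of 4-methoxyphenyl with the read-out staying within the scatter, although the entering group is larger by heavy-atom count and brings a carbonyl and a hydrogen-bond donor that the leaving group lacks. No measurement on hand gives a reason for this outcome.

The single step exchanges one ring-bearing group for another, so the compounds shown leave open how far the carbonyl, the amide hydrogen and the benzyl ring each matter on their own, and whether the tolerance seen here holds with a small group without a ring, such as acetyl. Also open, from the compounds shown here alone, is whether a longer chain such as phenethylcarbamoyl, or a carboxylic acid or an amine on the benzyl ring, would keep the read-out within the scatter of compound 4, and whether this result carries over to other aryl groups on the aromatic carbon.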